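A few compounds are considered here, and "the series" means these few. Any claim that something is new, unique, unknown or untested is made for them only; others in the source may bear on it.

Compound 1 `CC(=O)N1N=C(c2ccc(-n3cncn3)cc2)CC1c1ccc(N(C)C)cc1` gives 11% in a functional assay on HCC1806 cells (Homo sapiens) for inhibition, read by sulforhodamine B assay, tested at 10 uM (a higher number here means more inhibition at the concentration tested (going by the name of the read-out), a lower number less inhibition), at the single concentration tested. Going by the values given here, compound 2 `CN(C)c1ccc(C2CC(c3ccc(-n4cncn4)cc3)=NN2S(C)(=O)=O)cc1` gives 10.8% in this assay; the step of a number 0.2 percentage points lower from compound 1 to compound 2 (within the scatter) is within the scatter, so compound 2 sits level with compound 1, the only other number in the set, and both show little inhibition.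

Compound 3 `CN(C)c1ccc(C2CC(c3ccc(-n4cncn4)cc3)=NN2S(=O)(=O)c2ccc(Br)cc2)cc1` differs from compound 2 by 4-bromophenyl in place of methyl on a sulfonyl sulfur. Among the compounds with values here, the only measured step, a number 0.2 percentage points lower from compound 1 to compound 2 (within the scatter), exchanges the group on the ring nitrogen without touching the sulfonyl substituent, so it offers no direct precedent for this change; what it shows is that the read-out stayed low through one variation at that position.

Within the data shown here, with no step bearing on a 4-bromophenyl at the sulfonyl sulfur, compound 3 is expected to stay low, and the step of a number 4.2 percentage points higher from compound 2 to compound 3 (within the scatter) is expected to remain within the scatter. The estimate for compound 3 is 15%, with a range from 0% to 40%.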

Compound 3, a percentage reported as inhibition, at one concentration (the size of the read-out at that concentration, not a potency): 26.3%
Beside the measured number, compound 3's estimate is 11.3 percentage points below it; low and high end bracket the measured number.
By their numbers in this assay, from the lowest: compounds 2 and 1 (each within the scatter of the next); then compound 3.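

Going by these compounds alone, at the sulfonyl sulfur, the read-out in this assay responds to the group carried: 4-bromophenyl in place of methyl gives a number 15.5 percentage points higher from compound 2 to compound 3 (beyond the scatter) and is the first step in the set beyond the scatter. Replacing acetyl with (4-bromophenyl)sulfonyl on the ring nitrogen gives a number 15.3 percentage points higher from compound 1 to compound 3 (beyond the scatter) and is likewise beyond the scatter, whereas methylsulfonyl in place of acetyl left the two values level, so among these compounds the sulfonyl group alone does not go with the rise. Nothing available here accounts for this rise.

Open, as far as these compounds go, is whether the step follows the bromine or the phenyl ring itself, a question that a plain phenyl or a 4-chlorophenyl on the sulfonyl sulfur would address. Also open, from the compounds shown here alone, is how a naphthyl group or a longer chain at this position would read.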